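Swapping Fluoro for Methyl in a Growth Inhibitor

The source may report more compounds than this note shows. Statements on the series, on what has been measured and on what is new or still open speak of the compounds shown alone.

In a functional assay on NCI-H460 cells (Homo sapiens) for inhibition (a lower number here means a stronger inhibitor of growth, a higher number a weaker inhibitor of growth), compound 2 `Nc1ccc(-c2nc3ccccc3s2)cc1F` gives < 10 nM, which is a limit of the assay and not a number. Compound 2 therefore stands at the limit of < 10 nM in this assay, at which 1 of the 2 values shown sits. Compound 1 `Cc1cc(-c2nc3ccc(F)cc3s2)ccc1N` gives 100 nM in this assay. Compound 3 `Cc1cc(-c2nc3ccccc3s2)ccc1N` is the next case: methyl in place of fluoro on an aromatic carbon, ortho to an amino group. Among the measured compounds shown here, no measured pair of compounds differing in one place shows what such a change does. Compound 1 also carries a methyl group and gives a measurable 100 nM, so growth inhibition is expected to persist with methyl. In this assay, a small move toward weaker inhibition is expected, perhaps no more than the scatter, and the estimated step is a number no lower from compound 2 to compound 3 (the limit leaves the size open). For compound 3 the estimated value is 10 nM, with an expected range of 2 nM to 80 nM.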

Compound 3, concentration for 50% growth inhibition: 29500 nM
The estimate for compound 3 lay 3000-fold (3.47 log units) below the measured number; measured number outside the range, above it.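

In this assay, methyl in place of fluoro on an aromatic carbon, ortho to an amino group, gives an at least 2900-fold higher number from compound 2 to compound 3 (3.46 log units; beyond the scatter), so at this position the two groups are far from interchangeable. Going by these compounds, compound 2 gives < 10 nM, which is a limit of the assay, so the true size of this step stays open. The second step adds what compound 1 alone could not show: with methyl present, removing the second fluoro gives a 300-fold higher number from compound 1 to compound 3 (2.47 log units; beyond the scatter), so growth inhibition with methyl at this position depends strongly on that second fluoro.

The compounds shown leave open whether the loss follows from methyl arriving or from fluoro leaving. Hydrogen, chloro or methoxy at this same position would help separate the two.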